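Swapping the side chain on an aromatic ether

The source may report more compounds than this note shows. Statements on the series, on what has been measured and on what is new or still open speak of the compounds shown alone.

Three compounds were measured in a functional assay on HCT-116 cells (Homo sapiens) for cytotoxicity; on this read-out higher numbers stand for an effect only at larger amounts of compound and lower numbers for an effect already at smaller amounts:
Compound 1 `COc1ccc(S(=O)(=O)Nc2ccc(C(=O)CSC(C)=O)cn2)cc1` gives 540 nM.
Compound 2 `CC(=O)SCC(=O)c1ccc(NS(=O)(=O)c2ccc(OCc3ccccn3)cc2)nc1` gives 420 nM.
Compound 3 `CC(=O)SCC(=O)c1ccc(NS(=O)(=O)c2ccc3c(c2)COOC3)nc1` gives 1200 nM.

Compound 2 holds the lowest number of the three. Its nearest neighbour is compound 1: the step of a 1.3-fold lower number from compound 1 to compound 2 (0.11 log units; within the scatter) lies within the scatter, so the two cannot be set in order. Compound 3 stands furthest from compound 2, its number higher beyond the scatter.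

Compound 4 `CC(=O)SCC(=O)c1ccc(NS(=O)(=O)c2ccc(OCCCN3CCCCC3)cc2)nc1` has not been measured in this assay. It differs from compound 2 in one place: 2-(piperidin-1-yl)ethyl in place of pyridin-2-yl on a saturated chain carbon bound to an oxygen on an aromatic ring. For the measured compounds named here, only one measured step touches this place, the step of a 1.3-fold lower number from compound 1 to compound 2 (0.11 log units; within the scatter), and it stayed within the scatter. Going by the values given here, no measured pair shows what a non-aromatic ring on a longer chain does here, so the direction is open. Compound 4 is therefore expected to give a number near that of compound 2, with the step of a 1.2-fold higher number from compound 2 to compound 4 (0.08 log units; within the scatter) estimated to stay within the scatter. The estimate for compound 4 is 500 nM, ranging from 180 nM to 1500 nM.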

Compound 4, half-maximal effective concentration: 1000 nM
Beside the measured number, compound 4's estimate is 2.0-fold (0.30 log units) below it, and the stated range covers the measured number.
By their numbers in this assay, from the lowest: compounds 2, 1, 4 and 3 (each within the scatter of the next, the first and the last beyond it).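

In this assay, for the compounds shown here, the position on the saturated chain carbon bound to an oxygen on an aromatic ring now separates two groups for the first time: 2-(piperidin-1-yl)ethyl in place of pyridin-2-yl gives a 2.4-fold higher number from compound 2 to compound 4 (0.38 log units; beyond the scatter) and so the group at this place can matter. Measured against hydrogen at the same place, the same group gives a 1.9-fold higher number from compound 1 to compound 4 (0.27 log units; within the scatter) and compound 1 therefore cannot be set in order against either compound 2 or compound 4. Nothing at hand offers a reason for the difference between compound 2 and compound 4.

Compound 4 changes both the ring and the chain length, so the two changes cannot be told apart. A pyridin-2-yl on a longer chain, or a piperidin-1-yl on the shorter one, would separate them, while a morpholine ring or a carboxylic acid at the chain end remains untested among these compounds.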